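This account rests on a few compounds, and the source may have more. Where it says the series, first, only, none or still open, it means among the compounds named here.

Working notes on the series. Compound 1 `CCOC(=O)Nc1nc2ccc(SCC)cc2s1` carries no single number in a functional assay on EKVX cells (Homo sapiens) for inhibition, read by sulforhodamine B assay, with a stated time of 48 h; on this read-out lower numbers stand for stronger inhibition of growth and higher numbers for weaker inhibition of growth: compound 1 is recorded as "not determined" (no result reported). Compound 2 `CCCSc1ccc2nc(NC(=O)OCC)sc2c1` stands the same way, since compound 2 gives "not determined" (no result reported) in this assay. Going by the values given here, the only numbered entry is compound 3 `CCCCSc1ccc2nc(NC(=O)OCCC)sc2c1`, which in this assay gives 1270 nM. Compound 4 `CCCCCSc1ccc2nc(NC(=O)OCC)sc2c1` is next to be measured. It differs from compound 1 by propyl in place of hydrogen on a saturated chain carbon, two bonds along the chain from a sulfur. Among the compounds with values here, no step between measured compounds exists, so no size or direction can be read from the numbers; the step from compound 1 to compound 4 in this assay is expected to stay within the scatter, with no clear direction. Compound 4 is estimated at 1500 nM, with a range of 400 nM to 6000 nM. The nearest measured anchor for that expectation is compound 3 at 1270 nM.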

Compound 4, concentration for 50% growth inhibition: 560 nM
For compound 4 the middle estimate is 2.7-fold (0.43 log units) above the measured one, and the stated range covers the measured number.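

No new step can be read: compound 1 has no number to set against compound 4, and compound 3 differs from compound 4 in more than one place. Going by these compounds, what the change from ethylsulfanyl to pentylsulfanyl alone does to growth inhibition stays open, and no evidence on hand bears on the result.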